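This account rests on a few compounds, and the source may have more. Where it says the series, first, only, none or still open, it means among the compounds named here.

Working notes on the series.

Compound 2 `c1ccc(-c2cc[nH]n2)c(OCC2=NCCN2)c1` stands at 79.4 nM in a functional assay for activation of Alpha-1B adrenergic receptor (Homo sapiens), read by calcium flux; a higher number here means that more compound is needed for the effect, a lower number that less compound is needed. Its nearest measured neighbour is compound 1 `c1cncc(-c2ccccc2OCC2=NCCN2)c1`, which in this assay gives 79.4 nM. For the measured compounds named here, the one step measured so far, no change at the digits printed from compound 1 to compound 2 (within the scatter), replaced pyridin-3-yl with 1H-pyrazol-3-yl on the aromatic carbon and left the value where it was, within the scatter. So on the numbers in hand, compound 2 is level with compound 1 and nothing separates the two.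

Compound 3 `Cc1ccc(-c2ccccc2OCC2=NCCN2)s1` is not yet measured. The change from compound 2 is 5-methylthiophen-2-yl in place of 1H-pyrazol-3-yl on an aromatic carbon. The measured step bears on it only loosely: it shows that exchanging one aromatic ring for another at this carbon, a six-membered ring for a five-membered one with two hetero atoms, left this assay unchanged. Going by the values given here, no measured step tests the loss of the hydrogen-bond donor or the entry of a five-membered ring with one hetero atom and a methyl group. The expected step of a 1.3-fold higher number from compound 2 to compound 3 (0.10 log units; within the scatter) is therefore none beyond the scatter, with a wide allowance either way. Compound 3 is estimated at 100 nM, between 25 nM and 400 nM.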

Compound 3, half-maximal effective concentration: < 100000 nM
Compound 3: a limit, no number; the forecaster's own chance of this, stated with the estimate: 5%; the middle value is on the limit's open side.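

In this assay compound 3 gives < 100000 nM, which is a limit of the assay and not a number. The steps to compound 3 from compound 1 and from compound 2 cannot be read: the limit of < 100000 nM in this assay, at which 1 of the 3 values shown sits.

The compounds shown leave open whether 5-methylthiophen-2-yl on the aromatic carbon moves the value in this assay at all, and by how much.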